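A few compounds are considered here, and "the series" means these few. Any claim that something is new, unique, unknown or untested is made for them only; others in the source may bear on it.

Of the compounds shown here, three sharing one core have been tested in a functional assay on MCF7 cells (Homo sapiens) for cytotoxicity, read by MTT assay, with a stated time of 24 h; a lower number here means a stronger inhibitor, a higher number a weaker inhibitor. Compound 1 `COc1cc(/C=C(\C#N)C(=O)N/N=C(\C)c2c(O)c3ccc(O)cc3oc2=O)ccc1O` gives 13700 nM and compound 2 `COc1ccc(/C=C(\C#N)C(=O)N/N=C(\C)c2c(O)c3ccc(O)cc3oc2=O)cc1OC` gives 14400 nM, two values within the scatter of each other. Compound 3 `C/C(=N\NC(=O)/C(C#N)=C/c1ccc(N(C)C)cc1)c1c(O)c2ccc(O)cc2oc1=O` gives 3420 nM, the lowest number of the three and so the strongest inhibitor so far. Compound 4 `C/C(=N\NC(=O)/C(C#N)=C/c1cccc([N+](=O)[O-])c1)c1c(O)c2ccc(O)cc2oc1=O` changes one group of compound 3: 3-nitrophenyl in place of 4-(dimethylamino)phenyl on a double-bonded chain carbon bound to a double-bonded chain carbon. The two measured steps at this same place bear on it: a 4.0-fold lower number from compound 1 to compound 3 (0.60 log units; beyond the scatter) and a 4.2-fold lower number from compound 2 to compound 3 (0.62 log units; beyond the scatter). Both are modest, and both arrive at the 4-(dimethylamino)phenyl group. Compound 4 gives up that group, so a partial return toward compound 1 at 13700 nM is expected. Going by the values given here, no compound with 3-nitrophenyl has been measured, however, so the size of the step is uncertain. The expected change is a 2.6-fold higher number from compound 3 to compound 4 (0.42 log units; beyond the scatter), similar in size to those two steps but opposite in direction. For compound 4 the estimated value is 9000 nM, with an expected range of 3500 nM to 22000 nM.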

Compound 4, half-maximal inhibitory concentration: 16400 nM
Beside the measured number, compound 4's estimate is 1.8-fold (0.26 log units) below it, within the range that was stated.
By their numbers in this assay, from the lowest: compound 3; then compounds 1, 2 and 4 (each within the scatter of the next).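

In this assay the change to 3-nitrophenyl brings a 4.8-fold higher number from compound 3 to compound 4 (0.68 log units; beyond the scatter) and removes the whole of the advantage held by compound 3, as the readings of a 1.1-fold higher number from compound 2 to compound 4 (0.06 log units; within the scatter) and a 1.2-fold higher number from compound 1 to compound 4 (0.08 log units; within the scatter) show. Three different groups at this place on the double-bonded chain carbon, 3-nitrophenyl, 3,4-dimethoxyphenyl and 4-hydroxy-3-methoxyphenyl, therefore give numbers within the scatter of one another, and among these four compounds only 4-(dimethylamino)phenyl stands apart. Nothing measured here explains why that group differs.

Going by these compounds, it remains open whether the lower number needs the dimethylamino group itself or would also appear with another amine on the ring, such as a diethylamino group or a morpholine. A plain phenyl ring at this place would show how the groups compare with an unsubstituted ring.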